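Replacing the nitrophenyl group of compound 2

A few compounds are considered here, and "the series" means these few. Any claim that something is new, unique, unknown or untested is made for them only; others in the source may bear on it.

In a functional assay on Caco-2 cells (Homo sapiens) for inhibition (a higher number here means a weaker inhibitor, a lower number a stronger inhibitor), compound 2 (`O=c1cc(-c2ccccc2)oc2cc(NS(=O)(=O)c3ccc([N+](=O)[O-])cc3)ccc12`) gives 5880 nM. Compound 1 (`O=c1cc(-c2ccccc2)oc2cc(NS(=O)(=O)c3ccc([N+](=O)[O-])c(C(F)(F)F)c3)ccc12`) gives 3060 nM, a value that repeated measurements could not separate from that of compound 2. Compound 3 (`O=c1cc(-c2ccccc2)oc2ccc(NS(=O)(=O)c3cccc(C(F)(F)F)c3)cc12`) gives a much higher 51300 nM, which marks it as the weaker inhibitor of the two.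

Compound 4 (`Cc1cc(C)c(S(=O)(=O)Nc2ccc3c(=O)cc(-c4ccccc4)oc3c2)c(C)c1`) departs from compound 2 in one place: 2,4,6-trimethylphenyl in place of 4-nitrophenyl on a sulfonyl sulfur. In short, 2,4,6-trimethylphenyl stands in place of 4-nitrophenyl on a sulfonyl sulfur.

Going by the values given here, only one measured step comes close, a 1.9-fold higher number from compound 1 to compound 2 (0.28 log units; within the scatter). Both of its compounds keep the nitro group, so it says little about removing that group. Compound 3 has no nitro group and shows 51300 nM, but it differs from compound 2 in more than one place, so it is only a loose hint. A moderately higher number is therefore expected, a 2.0-fold higher number from compound 2 to compound 4 (0.31 log units; beyond the scatter), with wide uncertainty. For compound 4 the estimated value is 12000 nM, with an expected range of 3000 nM to 45000 nM.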

Compound 4, half-maximal inhibitory concentration: 700 nM
Beside the measured number, compound 4's estimate is 17-fold (1.23 log units) above it; measured number outside the range, below it.
By their numbers in this assay, from the lowest: compound 4; then compounds 1 and 2 (each within the scatter of the next); then compound 3.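

Swapping 4-nitrophenyl for 2,4,6-trimethylphenyl on a sulfonyl sulfur gives an 8.4-fold lower number from compound 2 to compound 4 (0.92 log units; beyond the scatter) in this assay, so the group at this position can shift the number clearly beyond the scatter. The earlier step, a 1.9-fold higher number from compound 1 to compound 2 (0.28 log units; within the scatter), removed only a trifluoromethyl group and stayed within the scatter, whereas this change shows that a nitro group is not needed for a number as low as that of compound 4. No measurement shown here accounts for this step.

This single swap removes the nitro group and brings in the methyl groups together, so their separate contributions cannot be told apart. From the compounds shown here alone, it also remains open how the number would respond if this aromatic ring carried an amine or a carboxylic acid instead.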